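Working notes: from compound 1 to compound 3

The source may report more compounds than this note shows. Statements on the series, on what has been measured and on what is new or still open speak of the compounds shown alone.

compound 1 `Cc1ccc(S(=O)(=O)N/C(=N\O)Nc2ccc(Cl)cc2)cc1`: 46 ug/mL
compound 2 `O=S(=O)(N/C(=N\O)Nc1ccc(Cl)cc1)c1cc2ccccc2s1`: 55 ug/mL

Both numbers come from a functional assay on KB cells (Homo sapiens) for cytotoxicity; on this read-out higher numbers stand for weaker inhibition and lower numbers for stronger inhibition. Compound 1 at 46 ug/mL and compound 2 at 55 ug/mL lie within the scatter of each other, so compound 1 holds no separate place on these numbers.

The next compound to be measured is compound 3 `N#Cc1c(Cl)cccc1Oc1ccc(S(=O)(=O)N/C(=N\O)Nc2ccc(Cl)cc2)cc1`. It carries 3-chloro-2-cyanophenoxy in place of methyl on an aromatic carbon, para to a large group (3-chloro-2-cyanophenoxy in place of methyl on an aromatic carbon). The rest of the core of compound 1 stays as it is.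

Among the compounds with values here, no measured pair differs in one place only, so the series offers no step against which to size this change. The expectation in this assay therefore rests on the level of compound 1 at 46 ug/mL and on the size of the entering group, and it is held loosely. A modest move towards stronger inhibition is expected, of about the size of the scatter. The expected step is a 2.1-fold lower number from compound 1 to compound 3 (0.32 log units; beyond the scatter). For compound 3 the estimate is 22 ug/mL, with an expected range of 7 ug/mL to 60 ug/mL.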

Compound 3, half-maximal inhibitory concentration: 39 ug/mL
The estimate for compound 3 lay 1.8-fold (0.25 log units) below the measured number, and the stated range covers the measured number.
By their numbers in this assay, from the lowest: compounds 3, 1 and 2 (each within the scatter of the next).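

Within the data shown here, this is the first step that differs in one place only, and it sizes the exchange of methyl for 3-chloro-2-cyanophenoxy on an aromatic carbon, para to a large group. In this assay the exchange gives a 1.2-fold lower number from compound 1 to compound 3 (0.07 log units; within the scatter), so on this read-out the two compounds cannot be told apart, even though the entering group brings an additional six-membered aromatic ring, a nitrile and a chlorine to this place. No measurement on hand offers an explanation for this result.

As far as these compounds go, a single exchange cannot show whether other groups at this place would also fall within the scatter of compound 1, and the effects of a hydrogen, a methoxy group, an amine or a carboxylic acid here remain open. From the compounds shown here alone, it also remains open whether the nitrile or the chlorine of 3-chloro-2-cyanophenoxy matters on its own, which a plain phenoxy group at the same place would help to separate.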